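A methyl added to the phenyl ring of compound 2

The source may report more compounds than this note shows. Statements on the series, on what has been measured and on what is new or still open speak of the compounds shown alone.

Two thiosemicarbazide-linked thiophenes have been measured in a functional assay on SK-MEL-28 cells (Homo sapiens) for inhibition, read by colorimetric assay and MTT assay, with a stated time of 72 h; a lower number here means a stronger inhibitor, a higher number a weaker inhibitor. Compound 1, `COc1cc(C(=O)NNC(=S)Nc2csc(-c3ccc(C)cc3)c2)cc(OC)c1OC`, gives 42000 nM there. Compound 2, `COc1ccc(C(=O)NNC(=S)Nc2csc(-c3ccccc3)c2)cc1OC`, gives 28000 nM in this assay, the lower of the two numbers, but the gap to compound 1 lies within the scatter of repeated measurements, so the two cannot be told apart on these data. Compound 2 differs from compound 1 in two places at once, so no single structural change can be read off from this pair.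

Compound 3, `COc1ccc(C(=O)NNC(=S)Nc2csc(-c3ccc(C)cc3)c2)cc1OC`, has not yet been measured in this assay. It differs from compound 2 by methyl in place of hydrogen on an aromatic carbon. Going by the values given here, no measured pair shows what this change alone does in this assay, so the expectation rests only on the weak activity of both known compounds. Compound 3 is expected to stay close to compound 2, with a step from compound 2 to compound 3 of a 1.1-fold higher number from compound 2 to compound 3 (0.03 log units; within the scatter), that is, no change beyond the scatter. The estimate for compound 3 in this assay is 30000 nM, with a range from 12000 nM to 75000 nM.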

Compound 3, half-maximal inhibitory concentration: 19000 nM
Compound 3: the middle estimate sits 1.6-fold (0.20 log units) above what was measured; low and high end bracket the measured number.
By their numbers in this assay, from the lowest: compounds 3, 2 and 1 (each within the scatter of the next, the first and the last beyond it).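

In this assay, the change from phenyl to 4-methylphenyl gives a 1.5-fold lower number from compound 2 to compound 3 (0.17 log units; within the scatter), so a methyl on this aromatic carbon, para to a large group, does not move the number beyond the scatter. The measured compounds now also include a pair that differs in one place and separates beyond the scatter, at a different aromatic carbon: hydrogen in place of methoxy gives a 2.2-fold lower number from compound 1 to compound 3 (0.34 log units; beyond the scatter), a modest step that shows the methoxy pattern matters more on these data than the methyl does. No independent measurement is available to explain either step.

Whether this para carbon responds to anything other than methyl remains open, since the compounds shown carry neither a chlorine atom, a hydroxyl, an amine nor a longer chain such as ethyl or propyl there. Going by these compounds alone, the single step involving the methoxy also leaves open whether that carbon would respond to a hydroxyl or a fluorine atom, or whether the step depends on the methoxy being removed outright.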